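Adding a Third Methoxy Group: Little Change Expected

A few compounds are considered here, and "the series" means these few. Any claim that something is new, unique, unknown or untested is made for them only; others in the source may bear on it.

Two compounds have so far been tested in a functional assay on HL-60 cells (Homo sapiens) for cytotoxicity, read by MTT assay, with a stated time of 24 h; a lower number here means a stronger inhibitor, a higher number a weaker inhibitor:

Compound 1 `COC(=O)/C(=C\c1ccc(OC(=O)c2ccc(OC)cc2)cc1)Sc1ccnc2cc(Cl)ccc12` gives 9090 nM
Compound 2 `COC(=O)/C(=C\c1ccc(OC(=O)c2ccc(OC)cc2OC)cc1)Sc1ccnc2cc(Cl)ccc12` gives 7640 nM

Compound 2 holds the lower of the two numbers, but the step of a 1.2-fold lower number from compound 1 to compound 2 (0.08 log units; within the scatter) lies within the scatter, so the two compounds cannot be ranked. Compound 3 `COC(=O)/C(=C\c1ccc(OC(=O)c2ccc(OC)c(OC)c2OC)cc1)Sc1ccnc2cc(Cl)ccc12` differs from compound 2 by methoxy in place of hydrogen on an aromatic carbon. Going by the values given here, the only measured step that bears on this kind of change is a 1.2-fold lower number from compound 1 to compound 2 (0.08 log units; within the scatter), a methoxy added to the same ring with no clear effect. A further methoxy is therefore expected to give a step of about a 1.1-fold lower number from compound 2 to compound 3 (0.04 log units; within the scatter), within the scatter. Compound 3 is estimated at 7000 nM, with a range from 3500 nM to 14000 nM.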

Compound 3, half-maximal inhibitory concentration: 2080 nM
Beside the measured number, compound 3's estimate is 3.4-fold (0.53 log units) above it; the measured number lies below the stated range.
By their numbers in this assay, from the lowest: compound 3; then compounds 2 and 1 (each within the scatter of the next).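

Methoxy on the ring carbon ortho to two methoxy groups gives a 3.7-fold lower number from compound 2 to compound 3 (0.57 log units; beyond the scatter) in this assay and so, unlike the earlier methoxy addition, this one has a clear effect on the number. The 2,3,4-trimethoxyphenyl group in place of 4-methoxyphenyl likewise gives a 4.4-fold lower number from compound 1 to compound 3 (0.64 log units; beyond the scatter) and sets compound 3 clearly apart from both others. No measurement here explains the difference. Still open, from the compounds shown here alone, is whether all three methoxy groups are needed, and whether a hydroxyl, a chlorine or an ethoxy at this position would do the same.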